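A few compounds are considered here, and "the series" means these few. Any claim that something is new, unique, unknown or untested is made for them only; others in the source may bear on it.

Three compounds have been measured in a functional assay on A549 cells (Homo sapiens) for cytotoxicity, read by MTT assay, with a stated time of 72 h; a higher number here means a weaker inhibitor, a lower number a stronger inhibitor:

Compound 1 `CCCOCNc1n[n+]([O-])c2cc(OC)ccc2[n+]1[O-]` gives 2810 nM
Compound 2 `[O-][n+]1nc(NCOC2CCCCC2)[n+]([O-])c2ccccc21` gives 5180 nM
Compound 3 `O=[N+]([O-])c1cccc(COCNc2n[n+]([O-])c3ccccc3[n+]2[O-])c1` gives 2890 nM

Among these three, compound 2 carries the highest number, yet its gap to compound 3 and its gap to compound 1 both fall within the usual scatter of repeated measurements, so no order among the three can be claimed from these figures. The three share a core and differ only in the group attached through the oxygen on the saturated carbon, and on the evidence so far those variations have not moved the number beyond the scatter.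

Compound 4 `COCNc1n[n+]([O-])c2ccccc2[n+]1[O-]` has not yet been measured in this assay. It differs from compound 2 by methyl in place of cyclohexyl on an oxygen on a saturated carbon. Within the data shown here, no step between two measured compounds isolates this kind of change, so the expectation for compound 4 rests on the three numbers clustering together. The step is expected to be small, a 1.3-fold lower number from compound 2 to compound 4 (0.11 log units; within the scatter), with no direction beyond the scatter. Compound 4 is therefore estimated at 4000 nM, with a range from 1500 nM to 12000 nM.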

Compound 4, half-maximal inhibitory concentration: 7450 nM
Estimate against measurement, compound 4: 1.9-fold (0.27 log units) below, within the range that was stated.
By their numbers in this assay, from the lowest: compounds 1, 3, 2 and 4 (each within the scatter of the next, the first and the last beyond it).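

In this assay, among these compounds, the exchange of cyclohexyl for methyl on an oxygen on a saturated carbon gives the first single-change step at this place, a 1.4-fold higher number from compound 2 to compound 4 (0.16 log units; within the scatter). Going from 6 heavy atoms and a six-membered non-aromatic ring of carbon only to 1 heavy atom and no ring therefore leaves the two numbers indistinguishable, so this pair gives no sign that the size of this group matters in this assay. Nothing available explains this result or bears on it.

From the compounds shown here alone, whether an amine, a carboxylic acid or a longer chain on this oxygen would carry the number beyond the scatter remains open. Steps involving compound 1 or compound 3 cannot be read, as neither differs from another compound shown in one place only.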